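This account rests on a few compounds, and the source may have more. Where it says the series, first, only, none or still open, it means among the compounds named here.

Measured compounds:
compound 1 `c1ccc(CCCNC2CCc3ccsc3CC2)cc1`: 5.1 nM
compound 2 `c1ccc(CCCCNC2CCc3ccsc3CC2)cc1`: 5.7 nM
compound 3 `CCN(CCCc1ccccc1)C1CCc2ccsc2CC1`: 33 nM

In an assay on membranes from liver for displacement of a labelled ligand from Sigma intracellular receptor 2 (Rattus norvegicus), read by scintillation counting, with a stated time of 120 min, in the presence of a further agent that is not named here (a lower number here means a stronger inhibitor, a higher number a weaker inhibitor), compound 1 holds the lowest of the three numbers, with compound 2 inside the scatter of it, a 1.1-fold higher number from compound 1 to compound 2 (0.05 log units; within the scatter), and compound 3 further off, a 6.5-fold higher number from compound 1 to compound 3 (0.81 log units; beyond the scatter). Compound 4 `Brc1cc2c(s1)CCC(NCCCc1ccccc1)CC2` differs from compound 1 by bromo in place of hydrogen on an aromatic carbon. Neither measured step touches the aromatic part of the core: one alters the chain, the other the amine nitrogen, so neither bears directly on this change. Going by the values given here, there is no precedent for substitution on the ring, and the working expectation is therefore a step that does not clearly exceed the scatter. Compound 4 is expected at 6 nM, ranging from 2.5 nM to 15 nM. The expected step is a 1.2-fold higher number from compound 1 to compound 4 (0.07 log units; within the scatter).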

Compound 4, inhibition constant: 43 nM
Estimate against measurement, compound 4: 7.2-fold (0.86 log units) below; the measured number lies above the stated range.
By their numbers in this assay, from the lowest: compounds 1 and 2 (each within the scatter of the next); then compounds 3 and 4 (each within the scatter of the next).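

In this assay the aromatic carbon next to the ring sulfur proves sensitive: bromo in place of hydrogen there gives an 8.4-fold higher number from compound 1 to compound 4 (0.93 log units; beyond the scatter) in this series. Going by these compounds alone, this is the first sign that a change on the aromatic part of the shared core, and not only on the chain or the amine nitrogen, can move the number. Nothing on hand accounts for the rise. As far as these compounds go, whether it belongs to bromo itself or to any group at this carbon stays open. Chloro or methyl at the same carbon would help separate these readings.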